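Compound 2 and a Tert-Butyl Step

This account rests on a few compounds, and the source may have more. Where it says the series, first, only, none or still open, it means among the compounds named here.

In a physicochemical assay for lipophilicity, read by HPLC, measured as octanol-water partition (on this read-out lower numbers stand for lower lipophilicity and higher numbers for higher lipophilicity), compound 2 `O=C(N/N=C/c1ccc2no[n+]([O-])c2c1)c1ccccc1` gives 2.2, and compound 1 `Nc1ccccc1C(=O)N/N=C/c1ccc2no[n+]([O-])c2c1` gives 2, a pair separated by a number 0.20 log units higher from compound 1 to compound 2 (within the scatter). Compound 3 `Nc1cccc(C(=O)N/N=C/c2ccc3no[n+]([O-])c3c2)c1` gives 1.4. The other two measured steps are a number 0.60 log units lower from compound 1 to compound 3 (beyond the scatter) and a number 0.80 log units lower from compound 2 to compound 3 (beyond the scatter). Compound 4 `CC(C)(C)c1ccc(C(=O)N/N=C/c2ccc3no[n+]([O-])c3c2)cc1` has not yet been measured. It carries tert-butyl in place of hydrogen on an aromatic carbon of compound 2: tert-butyl in place of hydrogen on an aromatic carbon. For the measured compounds named here, no measured step involves tert-butyl, and the steps among the three amino-related compounds serve only as a scale. An upward move beyond the scatter, larger than any of these, is expected, and the estimated change is a number 1.50 log units higher from compound 2 to compound 4 (beyond the scatter). For compound 4 the estimate is 3.7, with an expected range from 3.1 to 4.3.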

Compound 4, partition coefficient: 3.8
Beside the measured number, compound 4's estimate is 0.10 log units below it; the range from low to high includes it.
By their numbers in this assay, from the lowest: compound 3; then compounds 1 and 2 (each within the scatter of the next); then compound 4.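

In this assay, for the compounds shown here, tert-butyl in place of hydrogen on an aromatic carbon, para to a large group, gives a number 1.60 log units higher from compound 2 to compound 4 (beyond the scatter) and so exceeds every step among the earlier compounds. Going by these compounds alone, it also runs opposite to a number 0.80 log units lower from compound 2 to compound 3 (beyond the scatter) and shows that changes made to compound 2 can move the number in either direction, and further upward than the earlier steps had moved it. As far as these compounds go, whether methyl, a longer chain or a carboxylic acid at this same place would move the number as far remains open. Nothing measured here accounts for the size of this step.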